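Tetrazolyl for pyrimidinyl on the thioether of compound 1

This account rests on a few compounds, and the source may have more. Where it says the series, first, only, none or still open, it means among the compounds named here.

Compound 1 `O=C(CSc1ncccn1)N/N=c1/scc(-c2ccc([N+](=O)[O-])cc2)n1-c1ccccc1` carries a nitrophenyl group on the shared core. In a functional assay on C6 cells (Rattus norvegicus) for cytotoxicity, read by MTT assay, with a stated time of 24 h (a lower number here means a stronger inhibitor, a higher number a weaker inhibitor), compound 1 gives "not determined" (no result reported), so no number places it. Compound 2 `O=C(CSc1ncccn1)N/N=c1/scc(-c2ccccc2)n1-c1ccccc1` likewise gives "not determined" (no result reported) in this assay. For the measured compounds named here, compound 3 `O=C(CSc1ncccn1)N/N=c1/scc(-c2ccc(Br)cc2)n1-c1ccccc1` is the only member with a reported entry, and that entry is a limit of the assay: in this assay compound 3 gives > 200 ug/mL. Going by the values given here, the series therefore offers the limit of > 200 ug/mL in this assay, at which 1 of the 3 values shown sits, and nothing more, with no step between measured compounds to size.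

Compound 4 `Cn1nnnc1SCC(=O)N/N=c1/scc(-c2ccc([N+](=O)[O-])cc2)n1-c1ccccc1` differs from compound 1 by 1-methyl-1H-tetrazol-5-yl in place of pyrimidin-2-yl on a sulfur. Among the compounds with values here, with no measured step, no change beyond the usual scatter in this assay is expected, in either direction. Compound 4 is expected to give 250 ug/mL in this assay, within 100 ug/mL to 600 ug/mL, and most likely to return only a limit.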

Compound 4, half-maximal inhibitory concentration: > 200 ug/mL
Compound 4 ended at the assay's limit; the forecaster's own chance of this, stated with the estimate: 70%; the middle value does not contradict the limit.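

No step can be read from compound 1 to compound 4, as neither has a single number in this assay. Compound 4 gives > 200 ug/mL, a limit of the assay. The compounds shown leave open whether 1-methyl-1H-tetrazol-5-yl and pyrimidin-2-yl on the sulfur differ in this assay.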